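The compounds below may be only part of what the source reports. "The series", "measured", "known", "first", "only" and "open" are said of these compounds alone.

Measured so far:

Compound 1 `Cc1c(-c2cc(Cl)cc(Cl)c2)c(C(=O)O)nn1-c1nc(-c2cnn(C)c2)c(SC(C)C)s1`: "not active" (no number reported)
Compound 2 `Cc1cc(C#N)cc(-c2c(C)nn(-c3nc(-c4ccc(Cl)c(Cl)c4)c(SC(C)C)s3)c2C(=O)O)c1`: 4800 nM
Compound 3 `CCSc1sc(-n2nc(C)c(Cc3ccccc3[N+](=O)[O-])c2C(=O)OC)nc1-c1ccc(Cl)c(Cl)c1`: 106000 nM

All three were tested in a functional assay on BJAB cells (Homo sapiens) for antiproliferative activity, with a stated time of 4 days; on this read-out lower numbers stand for an effect already at smaller amounts and higher numbers for an effect only at larger amounts of compound. For compound 1 no number was reported in this assay, only that it showed no activity. Of the two compounds that did give a number, compound 2 stands at the lower one, and the gap to compound 3 is far beyond the usual scatter of this assay, so the two can be set in order with confidence.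

The next compound, compound 4 `Cc1nn(-c2nc(-c3ccc(Cl)c(Cl)c3)c(SC(C)C)s2)c(C(=O)O)c1-c1cccc(Cl)c1`, keeps the shared core of compound 2 and differs in one place: 3-chlorophenyl in place of 3-cyano-5-methylphenyl on an aromatic carbon. Going by the values given here, no pair of measured compounds differs by this single change, so there is no measured step that would tell how large its effect is. On the numbers alone, a newly shaped group on this ring carbon is expected to move the read-out only modestly, most likely toward a somewhat higher number or not beyond the scatter at all. The estimated step of a 1.5-fold higher number from compound 2 to compound 4 (0.16 log units; within the scatter) therefore stays small. For compound 4 the estimate in this assay is 7000 nM, with a range from 2000 nM to 25000 nM.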

Compound 4, half-maximal effective concentration: 13600 nM
Beside the measured number, compound 4's estimate is 1.9-fold (0.29 log units) below it; the range from low to high includes it.
By their numbers in this assay, from the lowest: compound 2; then compound 4; then compound 3.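

In this assay, going by these compounds alone, putting 3-chlorophenyl in place of 3-cyano-5-methylphenyl on this carbon of the five-membered ring gives a 2.8-fold higher number from compound 2 to compound 4 (0.45 log units; beyond the scatter), the first measured step at this position. The six-membered aromatic ring stays and only the groups it carries change, yet the step is beyond the usual scatter, so the read-out does respond to what this ring carries, though only modestly. The change removes a nitrile and a methyl and brings in a chlorine all at once, and no measurement shown here explains why the number moves.

On these data alone, with these compounds, the step cannot be divided between the nitrile, the methyl and the chlorine, so it remains unknown which of them matters most; a phenyl ring carrying only the nitrile or only the methyl would separate these contributions. As far as these compounds go, it also remains open how the read-out would respond to a quite different group at this position, such as an amine or a hydroxy group on the phenyl ring, or a plain unsubstituted phenyl.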